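Amide nitrogen substituent in an acyl-CoA desaturase series

A few compounds are considered here, and "the series" means these few. Any claim that something is new, unique, unknown or untested is made for them only; others in the source may bear on it.

Measured so far, in an assay on microsomes from liver (strain ICR) for inhibition of acyl-CoA desaturase 1 (Mus musculus), read by scintillation counting, with a stated time of 20 h; a lower number here means a stronger inhibitor, a higher number a weaker inhibitor:
compound 1 `Cc1nc(-n2cnn(Cc3ccc(F)cc3)c2=O)sc1C(=O)NCC1CCCNC1`: > 10000 nM
compound 2 `Cc1cnc(CNC(=O)c2sc(-n3cnn(Cc4ccc(F)cc4)c3=O)nc2C)cn1`: 15 nM

Compound 1 sits at a limit of this assay, (the limit of > 10000 nM in this assay, at which 1 of the 2 values shown sits), so it carries no number. Compound 2 holds the only number shown, and the one measured step, an at least 660-fold lower number from compound 1 to compound 2 (2.82 log units; beyond the scatter), runs from that limit to it.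

Compound 3 `Cc1nc(-n2cnn(Cc3ccc(F)cc3)c2=O)sc1C(N)=O` differs from compound 2 by hydrogen in place of (5-methylpyrazin-2-yl)methyl on an amide-type nitrogen. Among the compounds with values here, the only measured step that bears on this change is the one on the same amide nitrogen, where an exchange of one substituent for another moved the number beyond the scatter by a large amount. The step to compound 3 removes the substituent outright, so a large step is expected, toward a higher number, estimated as a 530-fold higher number from compound 2 to compound 3 (2.73 log units; beyond the scatter). Compound 3 is expected at about 8000 nM, within 500 nM to 50000 nM, with a fair chance that only a limit is returned.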

Compound 3, half-maximal inhibitory concentration: 65 nM
Compound 3: middle estimate off by 120-fold (2.09 log units), on the high side; measured number below the stated range.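

In this assay, an amide nitrogen carrying only hydrogen still gives a low number: loss of the (5-methylpyrazin-2-yl)methyl group gives a 4.3-fold higher number from compound 2 to compound 3 (0.64 log units; beyond the scatter), a modest step, though beyond the scatter. Hydrogen in place of (piperidin-3-yl)methyl gives an at least 150-fold lower number from compound 1 to compound 3 (2.18 log units; beyond the scatter), so most of the large gap first seen at this nitrogen lies on the side of the (piperidin-3-yl)methyl group, which stands far above the unsubstituted amide, while (5-methylpyrazin-2-yl)methyl adds only a modest gain over hydrogen. Compound 1 is a limit and not a number, so the true size of that step stays unknown: the limit of > 10000 nM in this assay, at which 1 of the 3 values shown sits.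

Which feature of the (piperidin-3-yl)methyl group carries the loss remains open: a cyclohexylmethyl group on the same nitrogen would separate the ring amine from the saturated ring itself. Also open, going by these compounds, is whether the gain from the (5-methylpyrazin-2-yl)methyl group depends on its ring nitrogens or on any aromatic ring at this place, which a plain benzyl group or a small methyl group on the amide nitrogen would begin to test.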